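The source may hold more compounds than are shown below. What is called first, only, known or untested is meant among the compounds shown, and "the series" means these compounds.

In a functional assay on DU-145 cells (Homo sapiens) for cytotoxicity, read by MTT assay (on this read-out higher numbers stand for weaker inhibition and lower numbers for stronger inhibition), compound 1 `CC(C)=CC[C@@H](OC(=O)CC(O)c1ccccc1)C1=CC(=O)c2c(O)ccc(O)c2C1=O` gives 17000 nM and compound 2 `CCCCC(C)(O)CC(=O)O[C@H](CC=C(C)C)C1=CC(=O)c2c(O)ccc(O)c2C1=O` gives 76500 nM on the shared core. Compound 3 `CCC(CO[C@H](CC=C(C)C)C1=CC(=O)c2c(O)ccc(O)c2C1=O)OC` gives 45700 nM in the same test, within the scatter of compound 2 and beyond the scatter on the higher side of compound 1.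

The change to compound 4 `CCC(O)(CC)CC(=O)O[C@H](CC=C(C)C)C1=CC(=O)c2c(O)ccc(O)c2C1=O` is (2-ethyl-2-hydroxybutyl)carbonyl in place of 2-methoxybutyl on an oxygen on a saturated carbon and places (2-ethyl-2-hydroxybutyl)carbonyl where 2-methoxybutyl stood, on an oxygen on a saturated carbon. Within the data shown here, two measured steps bear on it. The step of a 1.7-fold lower number from compound 2 to compound 3 (0.22 log units; within the scatter) replaced (2-hydroxy-2-methylhexyl)carbonyl by 2-methoxybutyl and stayed within the scatter, and the present change runs nearly the reverse way. The step of a 4.5-fold higher number from compound 1 to compound 2 (0.65 log units; beyond the scatter) was modest and removed hydroxy(phenyl)methyl, a group that compound 4 also lacks, so compound 2 is the closer reference.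

No shift beyond the scatter is therefore expected in this assay in either direction. The expected step is a 1.1-fold higher number from compound 3 to compound 4 (0.04 log units; within the scatter) in this test. For compound 4 the estimated value is 50000 nM with an expected range from 22000 nM to 110000 nM as the working bracket.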

Compound 4, half-maximal inhibitory concentration: 67000 nM
Estimate against measurement, compound 4: 1.3-fold (0.13 log units) below; measured number inside the range.
By their numbers in this assay, from the lowest: compound 1; then compounds 3, 4 and 2 (each within the scatter of the next).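

In this assay, the position takes (2-ethyl-2-hydroxybutyl)carbonyl in place of 2-methoxybutyl with no shift beyond the scatter, a 1.5-fold higher number from compound 3 to compound 4 (0.17 log units; within the scatter), and 1-ethyl-1-hydroxypropyl reads the same as 1-hydroxy-1-methylpentyl, a 1.1-fold lower number from compound 2 to compound 4 (0.06 log units; within the scatter). Hydroxy(phenyl)methyl now stands apart from a second open-chain group on the saturated chain carbon bound to a carbonyl carbon, a 3.9-fold higher number from compound 1 to compound 4 (0.60 log units; beyond the scatter), matching the earlier 4.5-fold higher number from compound 1 to compound 2 (0.65 log units; beyond the scatter). No measurement is at hand that explains these readings.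

From the compounds shown here alone, whether the lower number of compound 1 goes with the phenyl ring itself or with that ring and the hydroxy group together remains open. Also open, going by these compounds, is how an amine or a carboxylic acid on the chain would read in this assay.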